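Replacing a Hydroxy Group with a Thiadiazolylsulfanyl Arm

A few compounds are considered here, and "the series" means these few. Any claim that something is new, unique, unknown or untested is made for them only; others in the source may bear on it.

Compound 1 `CC1(C)O[C@H]2[C@H](OCc3noc(-c4ccc([N+](=O)[O-])cc4)n3)O[C@H](CSc3ncn[nH]3)[C@H]2O1`: > 100000 nM (a limit)
Compound 2 `CC1(C)O[C@H]2[C@H](OCc3noc(-c4ccc([N+](=O)[O-])cc4)n3)O[C@H](CO)[C@H]2O1`: 60000 nM

In a functional assay on SW1573 cells (Homo sapiens) for antiproliferative activity, read by sulforhodamine B assay, with a stated time of 48 h (on this read-out higher numbers stand for weaker inhibition of growth and lower numbers for stronger inhibition of growth), compound 1 reaches only the assay limit, > 100000 nM. Among the measured compounds shown here, compound 2 gives 60000 nM, the only outright number among the values shown. Compound 3 `CC1(C)O[C@H]2[C@H](OCc3noc(-c4ccc([N+](=O)[O-])cc4)n3)O[C@H](CSc3nnc(N)s3)[C@H]2O1` has not been measured. It differs from compound 2 by (5-amino-1,3,4-thiadiazol-2-yl)sulfanyl in place of hydroxy on a saturated chain carbon bound to a saturated ring carbon. For the measured compounds named here, one measured step bears on this: an at least 1.6-fold lower number from compound 1 to compound 2 (0.22 log units; that floor lies within the scatter), where a heteroaryl-sulfanyl group gave way to hydroxy; compound 3 runs the other way, placing a different heteroaryl-sulfanyl group on the same carbon. That step rests on a limit, (the limit of > 100000 nM in this assay, at which 1 of the 2 values shown sits), so its true size is not known. For compound 3 a step of a 1.7-fold higher number from compound 2 to compound 3 (0.22 log units; within the scatter) is therefore expected, toward a weaker number, quite possibly beyond the limit. Compound 3 is estimated at 100000 nM, ranging from 40000 nM to 300000 nM.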

Compound 3, concentration for 50% growth inhibition: > 100000 nM
Compound 3: only a limit was reported; the forecaster's own chance of this, stated with the estimate: 50%; the middle value lies on the limit itself.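

With (5-amino-1,3,4-thiadiazol-2-yl)sulfanyl in place of hydroxy on this saturated chain carbon, the result is an at least 1.6-fold higher number from compound 2 to compound 3 (0.22 log units; that floor lies within the scatter). Going by these compounds, compound 3 stops at a limit, so a second sulfur-linked aromatic ring joins the first in giving no outright number, and among the three compounds only the hydroxy compound has one; the true size of the step remains unknown. The step between compound 1 and compound 3, which exchange one ring for the other on the sulfur, cannot be read: the limit of > 100000 nM in this assay, at which 2 of the 3 values shown sit.

On these data alone, how far either sulfanyl compound lies past the limit stays open, as does any real ranking of the two rings. Also open, as far as these compounds go, is whether a simple amine or a carboxylic acid on this carbon would give a stronger number than compound 2 with its 60000 nM.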